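Pentyl in Place of Isopropyl: Expecting the Limit Again

The source may hold more compounds than are shown below. What is called first, only, known or untested is meant among the compounds shown, and "the series" means these compounds.

Measured so far in an assay on isolated protein for inhibition of myosin-2 (Bos taurus), read by spectrophotometry, with a stated time of 24 min; a lower number here means a stronger inhibitor, a higher number a weaker inhibitor:
compound 1 `C/C(=N\CC1CCCCC1)c1c(O)c2ccccc2[nH]c1=O` gives >= 100000 nM
compound 2 `C/C(=N\C(C)C)c1c(O)c2ccccc2oc1=O` gives >= 100000 nM
compound 3 `C/C(=N\C(C)C)c1c(O)c2ccccc2[nH]c1=O` gives >= 100000 nM

Every one of these readings is a limit of the assay and not a number. For compound 1 the value >= 100000 nM is such a limit. For compound 2 the value >= 100000 nM is such a limit. For compound 3 the value >= 100000 nM is such a limit. Compound 2 therefore stands nowhere in particular on the numbers shown: it sits at the same limit as the other two, which is the whole picture because all three values sit at the limit of >= 100000 nM in this assay, at which 3 of the 3 values shown sit. Within the data shown here, the only step between measured compounds that differ in one place, a step that the two limits leave unreadable from compound 1 to compound 3, is unreadable for the same reason.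

Compound 4 `CCCCC/N=C(\C)c1c(O)c2ccccc2oc1=O` has not been measured. It differs from compound 2 by pentyl in place of isopropyl on a double-bonded nitrogen. Among the measured compounds shown here, no measured step bears on this change in a readable way, since the one step between measured compounds cannot be read. The expected step of a number no higher from compound 2 to compound 4 (the limit leaves the size open) is therefore none beyond the scatter. Compound 4 is estimated at 100000 nM, with a range from 40000 nM to 300000 nM, most likely reported as a limit once more.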

Compound 4, half-maximal inhibitory concentration: 6700 nM
Compound 4: the middle estimate sits 15-fold (1.17 log units) above what was measured, outside the stated range (below it).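

Pentyl in place of isopropyl on a double-bonded nitrogen gives, in this assay, an at least 14-fold lower number from compound 2 to compound 4 (1.17 log units; beyond the scatter), so the group at this position can make a large difference to the reading. Compound 4 is the first compound shown with a readable number, 6700 nM. Compound 2 remains a limit of the assay, as do compound 1 and compound 3: the limit of >= 100000 nM in this assay, at which 3 of the 4 values shown sit.

This single pair cannot say whether the gain belongs to pentyl alone or would carry over to a longer chain such as octyl, or to a chain ending in an amine or a carboxylic acid. It also leaves open whether pentyl would give a comparable step on the core of compound 3, which carries isopropyl at the same position.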